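Hydrogen for ethynyl at a thioether: a cytotoxicity expectation

This account rests on a few compounds, and the source may have more. Where it says the series, first, only, none or still open, it means among the compounds named here.

Compound 1, `Cc1nnc(SCC(=O)c2ccc(Cl)cc2)n1N1C(=O)c2ccccc2C1=O`: > 200000 nM
Compound 2, `C#CCSc1nnc(-c2cc(OC)c(OC)c(OC)c2)n1N1C(=O)c2ccccc2C1=O`: > 200000 nM

Both readings come from a functional assay on PC-3M cells (Homo sapiens) for cytotoxicity, read by MTT assay, with a stated time of 48 h; a lower number here means a stronger inhibitor, a higher number a weaker inhibitor. For compound 1 the value > 200000 nM is a limit of the assay, not a number. For compound 2 the value > 200000 nM is likewise only a limit. Compound 2 thus stands at the limit of > 200000 nM in this assay, at which 2 of the 2 values shown sit. Compound 3, `COc1cc(-c2nnc(SC)n2N2C(=O)c3ccccc3C2=O)cc(OC)c1OC`, differs from compound 2 by hydrogen in place of ethynyl on a saturated chain carbon bound to a sulfur. Within the data shown here, no measured step covers this change, so no shift beyond the scatter is expected; the expected step is a number no higher from compound 2 to compound 3 (the limit leaves the size open). Compound 3 is estimated at 200000 nM in this assay, between 60000 nM and 600000 nM, most probably again reported as a limit.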

Compound 3, half-maximal inhibitory concentration: > 200000 nM
Compound 3: no number, only a limit; the forecaster's own chance of this, stated with the estimate: 80%; the middle value sits exactly at the limit.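

In this assay compound 3 gives > 200000 nM, which is a limit. Compound 2 gives > 200000 nM, also a limit, so no step can be read between compound 2 and compound 3. The compounds shown leave open whether propargyl to methyl shifts the reading at all, as none of them gives a number.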